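The source may hold more compounds than are shown below. What is called first, only, known or untested is meant among the compounds shown, and "the series" means these compounds.

Measured so far:
compound 1 `C[C@@H](O)[C@H]1C(=O)N2C(C(=O)OCOC(=O)C3CCCCC3)=C(S[C@@H]3CN[C@H](C(=O)Nc4cccc(C(=O)O)c4)C3)[C@H](C)[C@H]12` – > 95%
compound 2 `CC(C)OC(=O)c1cccc(NC(=O)[C@@H]2C[C@H](SC3=C(C(=O)O)N4C(=O)[C@H]([C@@H](C)O)[C@H]4[C@H]3C)CN2)c1` – > 95%

In a physicochemical assay for metabolic stability, read by LC-MS, in phosphate buffer, with a stated time of 3 h, at pH 7.4, tested at 50 uM (a higher number here means that more of the compound is left, a lower number that less of the compound is left), compound 1 gives > 95%, which is a limit of the assay rather than a number. In this assay compound 2 gives > 95%, likewise a limit. The common reading is the limit of > 95% in this assay, at which 2 of the 2 values shown sit. Compound 3 `COC(=O)OCOC(=O)C1=C(S[C@@H]2CN[C@H](C(=O)Nc3cccc(C(=O)O)c3)C2)[C@H](C)[C@@H]2[C@@H]([C@@H](C)O)C(=O)N12` differs from compound 1 by methoxy in place of cyclohexyl on a carbonyl carbon. Going by the values given here, no step between measured compounds is known, so nothing here points to a change beyond the usual scatter. Compound 3 is expected to give 94%, in the range 82% to 99%, most likely reported again as a limit. The expected step of a number at least 1 percentage points lower from compound 1 to compound 3 (that floor lies within the scatter) is an estimate of no real change.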

Compound 3, percent of the compound remaining: > 95%
Compound 3 gave a limit, no number (the forecaster's own chance of this, stated with the estimate: 65%); middle value at least 1 percentage points from the limit.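

No step can be read from compound 1 to compound 3, as both results in this assay are limits rather than numbers: the limit of > 95% in this assay, at which 3 of the 3 values shown sit.

The compounds shown leave open whether methoxy in place of cyclohexyl on a carbonyl carbon changes how much compound is left in this assay.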